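A few compounds are considered here, and "the series" means these few. Any claim that something is new, unique, unknown or untested is made for them only; others in the source may bear on it.

Compound 1, `O=C(NC(=O)c1ccccc1O)c1ccc(OC(F)(F)F)cc1`, is the weaker of the two compounds measured in an ADME assay on L6 cells (Rattus norvegicus) for cytotoxicity, read by resazurin assay, with a stated time of 72 h; a higher number here means a weaker inhibitor, a lower number a stronger inhibitor: in that assay compound 1 gives 84 ug/mL, while compound 2, `O=C(NC(=O)c1ccccc1O)c1ccc2ccccc2c1`, gives 21 ug/mL, a gap that lies beyond the scatter. Compound 3, `Nc1ccc(C(=O)NC(=O)c2ccccc2O)cc1`, has not been measured; it differs from compound 1 in one place, (amino in place of trifluoromethoxy on an aromatic carbon), with amino in place of trifluoromethoxy on an aromatic carbon. Among the measured compounds shown here, no measured pair here shows this change, so the step is expected to be small, a modest rise in the number, a 1.2-fold higher number from compound 1 to compound 3 (0.08 log units; within the scatter). Compound 3 is expected to give about 100 ug/mL in this assay, within a range from 40 ug/mL to 220 ug/mL.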

Compound 3, half-maximal inhibitory concentration: 39 ug/mL
The estimate for compound 3 lay 2.6-fold (0.41 log units) above the measured number, outside the stated range (below it).
By their numbers in this assay, from the lowest: compounds 2 and 3 (each within the scatter of the next); then compound 1.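

Among the compounds shown here, the step gives the first reading at this position: on an aromatic carbon para to a large group, amino in place of trifluoromethoxy brings a 2.2-fold lower number from compound 1 to compound 3 (0.33 log units; beyond the scatter) in this assay. The number therefore responds to this one change, and the swap moves it towards a stronger inhibitor. No measurement of any property bears on why the number moves. This remains a single pair, so it sets no trend for the position. As far as these compounds go, whether a hydroxyl, a methyl or a carboxylic acid in the same place would move the number the same way remains open.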